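The source may hold more compounds than are shown below. What is called first, only, known or untested is meant among the compounds shown, and "the series" means these compounds.

Of the compounds shown here, two have been tested in a functional assay on SH-SY5Y cells (Homo sapiens) for cytotoxicity, read by MTT assay; a lower number here means a stronger inhibitor, a higher number a weaker inhibitor. For compound 1 `COC(=O)[C@]1(Cc2ccc(O)c(CC=C(C)C)c2)OC(=O)C(O)=C1c1ccc(OC)cc1` the reading there is only a limit, < 10000 nM. Compound 2 `COc1cc(OC)c2c(c1CC=C(C)C)C[C@@H](C)OC2=O`, built on a different core, gives 8500 nM in this assay. Compound 3 `COC(=O)[C@]1(Cc2ccc(O)c(CC=C(C)C)c2)OC(=O)C(O)=C1c1ccccc1` is compound 1 with one change: hydrogen in place of methoxy on an aromatic carbon. For the measured compounds named here, no measured pair shows what this change does, and compound 1 itself sits at the limit of < 10000 nM in this assay, at which 1 of the 2 values shown sits, so the step can only be guessed. The step is expected to be small, a step that the limit leaves unreadable from compound 1 to compound 3, with no firm direction. Compound 3 is therefore estimated at 8000 nM, within a likely range from 2000 nM to 30000 nM.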

Compound 3, half-maximal inhibitory concentration: < 10000 nM
Compound 3 was reported as a limit (the forecaster's own chance of this, stated with the estimate: 40%); the middle value does not contradict the limit.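

Compound 1 and compound 3 are both reported only as limits in this assay, so no step can be read between them: the limit of < 10000 nM in this assay, at which 2 of the 3 values shown sit.

On these data alone, what going from 4-methoxyphenyl to phenyl does to the reading in this assay stays open.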